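A few compounds are considered here, and "the series" means these few. Any claim that something is new, unique, unknown or untested is made for them only; others in the source may bear on it.

The set holds three measured compounds and one awaiting measurement. Compound 1 `Cc1cc(C)c(CN2CCc3ccc(O[C@@H]4CCOC4)c(Cl)c3C2=O)c(=O)[nH]1` gives 28 nM in an assay on Sf9 cells for inhibition of histone-lysine N-methyltransferase EZH2 (Homo sapiens), read by scintillation counting, with a stated time of 60 min, in the presence of a further agent that is not named here; on this read-out higher numbers stand for weaker inhibition and lower numbers for stronger inhibition. Compound 3 `COc1ccc2c(c1Cl)C(=O)N(Cc1c(C)cc(C)[nH]c1=O)CCO2`, whose core is closed through a further ring, gives 650 nM in this assay. Compound 2 `COc1cccc(C(=O)NCc2c(C)cc(C)[nH]c2=O)c1F` is an open amide, and in this assay compound 2 reaches only the limit of the assay, > 150000 nM, so no number is known for it. It therefore stands at the limit of > 150000 nM in this assay, at which 1 of the 3 values shown sits, the weakest end of what the assay can report. Compound 4 `COc1cccc(C(=O)NCc2c(C)cc(C)[nH]c2=O)c1Cl` differs from compound 2 by chloro in place of fluoro on an aromatic carbon, ortho to a methoxy group. For the measured compounds named here, no measured pair shows this exchange, so its effect in this assay cannot be read from the data; a small step in either direction, or none beyond the scatter, is the plain expectation. Compound 4 is estimated to give 150000 nM in this assay, most likely between 30000 nM and 300000 nM, and most probably again only as a limit. The step this estimate implies is a number no higher from compound 2 to compound 4 (the limit leaves the size open), expected to stay within the scatter.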

Compound 4, half-maximal inhibitory concentration: 7200 nM
Beside the measured number, compound 4's estimate is 21-fold (1.32 log units) above it, and the stated range ends above it.
By their numbers in this assay, from the lowest: compound 1; then compound 3; then compound 4. At a limit, above all of these: compound 2.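

For the compounds shown here, until this result no pair of compounds spoke to this position. In this assay the exchange of fluoro for chloro on an aromatic carbon, ortho to a methoxy group, gives an at least 20-fold lower number from compound 2 to compound 4 (1.31 log units; beyond the scatter) and so lies well beyond the scatter, which shows that the open amide is sensitive to this single atom and that the small or absent step expected for it does not hold. Going by these compounds, the full size of the step remains unknown because compound 2 stands only at a limit: the limit of > 150000 nM in this assay, at which 1 of the 4 values shown sits.

Whether bromo or methyl in the same place would lower the number further remains open, as does what lies behind the step. Also open, on these data alone, is whether the exchange would count for as much on the closed cores of compound 1 and compound 3.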